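Series notes: benzylpiperidine ether amides, head-group variation

The compounds below may be only part of what the source reports. "The series", "measured", "known", "first", "only" and "open" are said of these compounds alone.

Measured so far:
compound 1 `Cc1cc(C(=O)O)ccc1CN1CCC[C@H](O[C@H](CO)c2ccnc(Cl)c2)[C@@H]1c1ccccc1` with 50000 nM in an assay on isolated protein for activation of cGMP-dependent protein kinase 1 (Homo sapiens), read by ADP-Glo, with stated times of 30 min and 2 h, in the presence of a further agent that is not named here; a lower number here means that less compound is needed, a higher number that more compound is needed for the effect
compound 2 `Nc1cc(C(=O)O)ccc1CN1CCC[C@H](O[C@H](CO)c2cc(Cl)cc(Cl)c2)[C@@H]1c1ccccc1` with 290 nM in this assay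
compound 3 `Cc1cc(C(=O)O)ccc1CN1CCC[C@H](O[C@H](CO)c2cc(Cl)cc(Cl)c2)[C@@H]1c1cccnc1` with 47000 nM in this assay

Compound 2 has the lowest number of the three, and its distance to compound 3 and to compound 1 lies beyond the scatter in both cases. Compound 1 and compound 3 differ from compound 2 in more than one place, so what the three values show of any single change is not separable here; what they do show is that the head group of compound 2 sits with the lowest number.

Compound 4 `COC(=O)c1ccc(CN2CCC[C@H](O[C@H](CO)c3cc(Cl)cc(Cl)c3)[C@@H]2c2ccccc2)c(C)c1` is not yet measured. It differs from compound 2 as follows: a group of 11 heavy atoms (9 carbon, 2 oxygen; one six-membered aromatic ring of carbon only) in place of a group of 10 heavy atoms (7 carbon, 1 nitrogen, 2 oxygen; one six-membered aromatic ring of carbon only), on a saturated chain carbon bound to an amine nitrogen in a ring. Among the compounds with values here, no step from a measured pair covers this change. Both of the other measured compounds, which carry a different head group, sit far above compound 2, so for the step from compound 2 to compound 4 a rise of the number is expected, estimated at a 28-fold higher number from compound 2 to compound 4 (1.44 log units; beyond the scatter). For compound 4 the expected value is 8000 nM, within 1000 nM to 50000 nM.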

Compound 4, half-maximal effective concentration: 900 nM
For compound 4 the middle estimate is 8.9-fold (0.95 log units) above the measured one, and the stated range ends above it.
By their numbers in this assay, from the lowest: compound 2; then compound 4; then compounds 3 and 1 (each within the scatter of the next).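

Within the data shown here, this is the first one-place comparison: in this assay, replacing 2-amino-4-carboxyphenyl on the saturated chain carbon bound to the ring amine nitrogen gives a 3.1-fold higher number from compound 2 to compound 4 (0.49 log units; beyond the scatter) and is a modest step. The place therefore accepts a group with 0 hydrogen-bond donors in place of one with 2, and compound 4 still reads 900 nM in this assay. The whole group changes in this single step, and no measurement offered here explains the rise in the number.

The share of the amino group and that of the carboxylic acid in this step stay unresolved, since the two are exchanged together. Also open, as far as these compounds go, is how a primary amide or a tetrazole at this place would read on the same core.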